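Swapping fluoro for trifluoromethyl on the thiourea aryl ring

The compounds below may be only part of what the source reports. "The series", "measured", "known", "first", "only" and "open" are said of these compounds alone.

Of the compounds shown here, three sharing one core have been measured in a functional assay on MKN-74 cells (Homo sapiens) for antiproliferative activity, with a stated time of 24 h; on this read-out higher numbers stand for weaker inhibition and lower numbers for stronger inhibition. Compound 1 `NC(=O)c1c(NC(=O)c2ccccc2Cl)sc2c1CCNC2` gives 28700 nM. Compound 2 `NC(=O)c1c(NC(=O)c2ccccc2Cl)sc2c1CCN(Cc1ccc([N+](=O)[O-])cc1)C2`, carrying a 4-nitrobenzyl group on the ring amine, gives 31500 nM, a change of a 1.1-fold higher number from compound 1 to compound 2 (0.04 log units; within the scatter). Compound 3 `NC(=O)c1c(NC(=O)c2ccccc2Cl)sc2c1CCN(C(=S)Nc1ccccc1F)C2`, where a thiourea-linked 2-fluorophenyl group replaces that hydrogen, gives 12600 nM; the step is a 2.3-fold lower number from compound 1 to compound 3 (0.36 log units; beyond the scatter), and from the nitrobenzyl analogue it is a 2.5-fold lower number from compound 2 to compound 3 (0.40 log units; beyond the scatter). Compound 3 therefore holds the lowest number of the three, with both neighbours beyond the scatter.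

Compound 4 `NC(=O)c1c(NC(=O)c2ccccc2Cl)sc2c1CCN(C(=S)Nc1ccccc1C(F)(F)F)C2` keeps everything of compound 3 except one change: trifluoromethyl in place of fluoro on an aromatic carbon. Within the data shown here, no measured step touches this aromatic carbon; the two informative steps, of modest size, concern what hangs on the ring amine, not the substituent on the phenyl ring. Among the measured compounds shown here, there is thus no direct precedent, and the expectation rests on the whole thiourea-aryl group already being present in compound 3. The estimated step in this assay is a 1.1-fold lower number from compound 3 to compound 4 (0.02 log units; within the scatter), meaning no change expected beyond the scatter. Compound 4 is estimated at 12000 nM, with a range from 4500 nM to 32000 nM.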

Compound 4, half-maximal inhibitory concentration: 1870 nM
Estimate against measurement, compound 4: 6.4-fold (0.81 log units) above; measured number below the stated range.
By their numbers in this assay, from the lowest: compound 4; then compound 3; then compounds 1 and 2 (each within the scatter of the next).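

In this assay, the group on this aromatic carbon, ortho to a large group, proves to be far from a minor detail: trifluoromethyl in place of fluoro gives a 6.7-fold lower number from compound 3 to compound 4 (0.83 log units; beyond the scatter), while the thiourea link and the shared core stay the same. This step is larger than either earlier step at the ring amine, a 2.3-fold lower number from compound 1 to compound 3 (0.36 log units; beyond the scatter) and a 2.5-fold lower number from compound 2 to compound 3 (0.40 log units; beyond the scatter), so in these compounds the read-out depends on the substituent on the aryl ring as well as on the group attached to the ring amine. Among these compounds, nothing given here explains why this exchange moves the number so far.

On these data alone, it remains open whether a chlorine atom, a methyl group or a methoxy group on this same aromatic carbon would give a number closer to that of compound 3 or compound 4, and what a plain phenyl ring with only hydrogen there would give. Also open, as far as these compounds go, is whether trifluoromethyl would give a similar step on a benzyl group attached directly to the ring amine, as in compound 2, or whether the step depends on the thiourea link.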